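This account rests on a few compounds, and the source may have more. Where it says the series, first, only, none or still open, it means among the compounds named here.

Working notes on the series. Among the measured compounds shown here, the shared core carries a nitrophenylhydrazone and an aroyl hydrazide; the three measured members differ only in the aroyl ring. Compound 1 `CC(/C=N/Nc1ccc([N+](=O)[O-])cc1)=N\NC(=O)c1ccc(N)cc1` gives 75000 nM in an ADME assay on J774 cells (Mus musculus, strain BALB/c) for cytotoxicity, read by resazurin assay, with a stated time of 72 h; a higher number here means that more compound is tolerated, a lower number that less compound is tolerated. Compound 3 `CC(/C=N/Nc1ccc([N+](=O)[O-])cc1)=N\NC(=O)c1ccc(C(F)(F)F)cc1` gives 78700 nM in this assay, and the two numbers sit within the scatter of each other, so neither can be placed above the other; the step of a 1.0-fold higher number from compound 1 to compound 3 (0.02 log units; within the scatter) says as much. For compound 2 `CC(/C=N/Nc1ccc([N+](=O)[O-])cc1)=N\NC(=O)c1ccccc1F` the value in this assay is a limit, > 100000 nM, as recorded in the limit of > 100000 nM in this assay, at which 1 of the 3 values shown sits. The step of an at least 1.3-fold higher number from compound 1 to compound 2 (0.12 log units; that floor lies within the scatter) is therefore only a floor, and that floor itself lies within the scatter.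

Compound 4 `COc1ccc(C(=O)N/N=C(C)/C=N/Nc2ccc([N+](=O)[O-])cc2)cc1` has not been measured. Against compound 3 the change is methoxy in place of trifluoromethyl on an aromatic carbon. For the measured compounds named here, of the measured steps, the one from compound 1 to compound 3 is the only exchange of a para substituent on the aroyl ring, and it moved the number hardly at all; the step to compound 2 changes both the group and its place and ends at a limit, so it bears less directly. For compound 4 no step beyond the scatter is expected: the estimated step is a 1.0-fold higher number from compound 3 to compound 4 (0.01 log units; within the scatter). The expected value for compound 4 in this assay is 80000 nM, with a range from 40000 nM to 160000 nM.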

Compound 4, half-maximal cytotoxic concentration: > 100000 nM
Compound 4 was reported as a limit (the forecaster's own chance of this, stated with the estimate: 35%); middle value at least 1.2-fold (0.09 log units) away from the limit.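

Compound 4, with methoxy on this aromatic carbon, para to a large group, is recorded only as a limit in this assay, so a second member of the series now stands there: the limit of > 100000 nM in this assay, at which 2 of the 4 values shown sit. Among the compounds shown here, this is the first exchange at this position that brings in a hydrogen-bond acceptor, and the floors an at least 1.2-fold higher number from compound 3 to compound 4 (0.10 log units; that floor lies within the scatter) and an at least 1.3-fold higher number from compound 1 to compound 4 (0.12 log units; that floor lies within the scatter) show no fall in the number, though both lie within the scatter, so methoxy cannot be placed above trifluoromethyl or amino here. The step between compound 2 and compound 4 cannot be read, since both values are limits, and neither compound can be ordered against the other.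

Still open, going by these compounds, is whether any group on this aromatic carbon separates from the others in this assay, for instance a carboxylic acid, a nitrile or a longer chain such as ethoxy. The compounds shown also leave open whether the number responds to a change outside the aroyl ring, such as replacing the nitro group of the shared core with an amine.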